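The source may hold more compounds than are shown below. What is called first, only, known or untested is meant among the compounds shown, and "the series" means these compounds.

Compound 1 `O=C1C=C[C@]2(C[C@@H](c3cccc([N+](=O)[O-])c3)O[C@@H](c3ccccc3)O2)O1` gives 370 nM
Compound 2 `O=C1C=C[C@]2(C[C@@H](c3ccccc3)O[C@@H](c3cccc([N+](=O)[O-])c3)O2)O1` gives 340 nM

In a functional assay on MJ cells (Homo sapiens) for antiproliferative activity, with a stated time of 48 h (on this read-out higher numbers stand for weaker inhibition and lower numbers for stronger inhibition), compound 2 stands at 340 nM and compound 1 at 370 nM which places the two within the usual scatter of each other, so neither can be ranked above the other. Compound 3 `O=C1C=C[C@]2(C[C@@H](c3ccccc3)O[C@@H](c3ccccc3)O2)O1` differs from compound 2 in one place, with hydrogen in place of nitro on an aromatic carbon and so carries no nitro group. Going by the values given here, no measured compound lacks that group, which leaves this change untested. Compound 1 and compound 2 each carry one nitro group, and with only their close values to go on, a small step toward a somewhat higher number is expected, perhaps none beyond the scatter. The estimated change is a 1.3-fold higher number from compound 2 to compound 3 (0.12 log units; within the scatter) and it remains a rough expectation. For compound 3 the expected value is 450 nM with an estimated range from 150 nM to 1300 nM in this assay as the test.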

Compound 3, half-maximal inhibitory concentration: 1700 nM
Compound 3: the middle estimate sits 3.8-fold (0.58 log units) below what was measured; the whole stated range lies below it.
By their numbers in this assay, from the lowest: compounds 2 and 1 (each within the scatter of the next); then compound 3.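

In this assay, replacing the nitro group with hydrogen gives a 5.0-fold higher number from compound 2 to compound 3 (0.70 log units; beyond the scatter) and a 4.6-fold higher number from compound 1 to compound 3 (0.66 log units; beyond the scatter), both beyond the usual scatter, so inhibition becomes weaker in each case. Every earlier compound carried a nitro group, so only now is it clear that this group matters on this read-out, and the loss appears whichever of the two aromatic rings held it. Nothing available here explains why the group makes this difference.

As far as these compounds go, whether a nitrile, an amine or a carboxylic acid on the same aromatic carbon could do what the nitro group does remains open. So does the question of what a nitro group on both aromatic rings at once would give.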